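A few compounds are considered here, and "the series" means these few. Any claim that something is new, unique, unknown or untested is made for them only; others in the source may bear on it.

Compound 1 `CCN(CC)CCNC(=O)c1ccc(C(CC)(CC)c2ccc(OCS(=O)(=O)c3ccccc3)c(C)c2)n1CC` gives 4680 nM in a functional assay on MCF7 cells (Homo sapiens) for antiproliferative activity, read by MTT assay, with a stated time of 24 h; on this read-out higher numbers stand for weaker inhibition and lower numbers for stronger inhibition.
Compound 2 `CCn1c(C(=O)NCCO)ccc1C(CC)(CC)c1ccc(OCS(=O)(=O)c2ccccc2)c(C)c1` gives 15500 nM.
Compound 3 `CCn1c(C(=O)N[C@@H](CO)CCCO)ccc1C(CC)(CC)c1ccc(OCS(=O)(=O)c2ccccc2)c(C)c1` gives 29600 nM.

Compound 2 stands second highest of the three numbers: compound 1 sits clearly lower, with a 3.3-fold higher number from compound 1 to compound 2 (0.52 log units; beyond the scatter), while compound 3 sits only a little higher, with a 1.9-fold higher number from compound 2 to compound 3 (0.28 log units; within the scatter), a gap that stays within the scatter.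

Compound 4 `CCn1c(C(=O)N[C@@H](CC(=O)O)C(=O)O)ccc1C(CC)(CC)c1ccc(OCS(=O)(=O)c2ccccc2)c(C)c1` has not been measured. It differs from compound 2 in one place: 1,2-dicarboxyethyl in place of 2-hydroxyethyl on an amide-type nitrogen. The change replaces the 2-hydroxyethyl group with a 1,2-dicarboxyethyl group on the amide-type nitrogen whose other neighbour is the carbonyl carbon.

For the measured compounds named here, two measured steps bear on this. Replacing the diethylamino group of compound 1 with a hydroxy group gave a 3.3-fold higher number from compound 1 to compound 2 (0.52 log units; beyond the scatter), and the larger exchange on the amide-type nitrogen from compound 1 to compound 3 gave a 6.3-fold higher number from compound 1 to compound 3 (0.80 log units; beyond the scatter). Extending the group on compound 2 to that of compound 3 gave a 1.9-fold higher number from compound 2 to compound 3 (0.28 log units; within the scatter). Each change in this direction has raised the number, so a further rise for compound 4, modest in size, is expected, as a 1.9-fold higher number from compound 2 to compound 4 (0.29 log units; within the scatter). Compound 4 is therefore estimated at 30000 nM, with a range from 12000 nM to 80000 nM.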

Compound 4, half-maximal inhibitory concentration: > 50000 nM
Compound 4: a limit, no number; the forecaster's own chance of this, stated with the estimate: 25%; middle value at least 1.6-fold (0.22 log units) from the limit.
By their numbers in this assay, from the lowest: compound 1; then compounds 2 and 3 (each within the scatter of the next). At a limit, above all of these: compound 4.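

In this assay compound 4 gives > 50000 nM as a limit of the assay and not a number, so its place in the series can be read only from one side. On the amide-type nitrogen, 1,2-dicarboxyethyl in place of 2-hydroxyethyl gives an at least 3.2-fold higher number from compound 2 to compound 4 (0.50 log units; beyond the scatter) and, in place of 2-(diethylamino)ethyl, gives an at least 10-fold higher number from compound 1 to compound 4 (1.02 log units; beyond the scatter) as the widest gap among the compounds shown, so this position can take the read-out to the limit of the assay, further than the earlier compounds showed. Against the group of compound 3 the result is less firm, since an at least 1.6-fold higher number from compound 3 to compound 4 (0.22 log units; that floor lies within the scatter) is a step whose floor does not separate the two compounds.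

The compounds shown leave open how far compound 4 lies past its limit, and they give no cause for the step. They also leave open whether a single carboxylic acid on a two-carbon chain, a methyl ester of the two acid groups, or a primary amine on the same nitrogen would stay nearer to compound 1 or compound 2.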